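Swapping fluoro for chloro on two closely related cores

The source may hold more compounds than are shown below. What is called first, only, known or untested is meant among the compounds shown, and "the series" means these compounds.

The measured compounds:
compound 1, `COc1cccc(S(=O)(=O)/C=C/c2ncccc2F)c1`, 100%
compound 2, `COc1cccc(S(=O)(=O)/C=C/c2ncccc2Cl)c1`, 100%
compound 3, `COc1ccc(S(=O)(=O)/C=C/c2ncccc2F)cc1`, 94.2%

All three were tested in an ADME assay on BV-2 cells (Mus musculus) for cytotoxicity, with a stated time of 24 h, tested at 10 uM; on this read-out lower numbers stand for a stronger effect and higher numbers for a weaker effect at the one concentration tested. Compound 2 differs from compound 1 by chloro in place of fluoro on an aromatic carbon, and this gave no change at the digits printed from compound 1 to compound 2 (within the scatter). Compound 3 has the same atoms as compound 1, joined differently; the difference between the two cores is not broken down here. Compound 4, `COc1ccc(S(=O)(=O)/C=C/c2ncccc2Cl)cc1`, has not been measured yet. It differs from compound 3 by chloro in place of fluoro on an aromatic carbon, the same change as that from compound 1 to compound 2. Compound 4 is expected to show a number 0.8 percentage points higher from compound 3 to compound 4 (within the scatter), because the matching step gave no change at the digits printed from compound 1 to compound 2 (within the scatter). Compound 4 is therefore estimated at 95%, with a likely range from 84% to 104%.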

Compound 4, a percentage reported as activity, at one concentration (the size of the read-out at that concentration, not a potency): 94.7%
For compound 4 the middle estimate is 0.3 percentage points above the measured one; low and high end bracket the measured number.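

In this assay, chloro in place of fluoro on an aromatic carbon gave a number 0.5 percentage points higher from compound 3 to compound 4 (within the scatter), and the step on the core of compound 3 matches the one on the core of compound 1: the same change on two cores in this assay, no change at the digits printed (within the scatter) from compound 1 to compound 2 and a number 0.5 percentage points higher (within the scatter) from compound 3 to compound 4, 0.5 percentage points apart, within the scatter of two such steps

The change therefore carries across these two cores, with neither step standing out from the scatter. Within the data shown here, this rests on only two pairs in one assay, so it sets no rule for any further core or any other read-out.

The compounds shown carry only fluoro or chloro at this place on the ring, so how bromo, a nitrile or an amine there would read in this assay stays open. Also open, on these data alone, is whether the two cores would keep matching with such groups.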